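A few compounds are considered here, and "the series" means these few. Any claim that something is new, unique, unknown or untested is made for them only; others in the source may bear on it.

Of the compounds shown here, three have been measured so far. Compound 1 `COc1cc(NC(C)CCCNC(=O)Nc2ccc(O)cc2)c2ncccc2c1` gives 5200 nM in a functional assay on MCF7 cells (Homo sapiens) for inhibition, read by MTT assay, with a stated time of 72 h; on this read-out lower numbers stand for stronger inhibition and higher numbers for weaker inhibition. Compound 2 `COc1cc(NC(C)CCCNC(=O)Nc2cccc(O)c2)c2ncccc2c1` gives 11000 nM in this assay. Compound 3 `COc1cc(NC(C)CCCNC(=O)Nc2ccc(Br)cc2)c2ncccc2c1` gives 2600 nM in this assay.

Compound 1 stands second highest of the three numbers, with compound 3 within the scatter of it and compound 2 above it. Exchanging its 4-hydroxyphenyl for 3-hydroxyphenyl gave a 2.1-fold higher number from compound 1 to compound 2 (0.33 log units; beyond the scatter), while putting bromo in place of the hydroxy gave a 2.0-fold lower number from compound 1 to compound 3 (0.30 log units; within the scatter); between those two compounds, a 4.2-fold lower number from compound 2 to compound 3 (0.63 log units; beyond the scatter).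

Compound 4 `COc1cc(NC(C)CCCNC(=O)Nc2ccc(Cl)cc2)c2ncccc2c1` has not yet been measured in this assay. It differs from compound 1 in one place: chloro in place of hydroxy on an aromatic carbon. Going by the values given here, the step that bears on it most directly is the one from compound 1 to compound 3, where another halogen took the place of the same hydroxy and the number did not change beyond the scatter. Something similar is expected here, so the step of a 1.6-fold lower number from compound 1 to compound 4 (0.21 log units; within the scatter) is expected to stay within the scatter. Compound 4 is therefore estimated at 3200 nM, with a range of 1500 nM to 6500 nM.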

Compound 4, half-maximal inhibitory concentration: 12000 nM
Compound 4: the middle estimate sits 3.8-fold (0.57 log units) below what was measured; measured number above the stated range.
By their numbers in this assay, from the lowest: compounds 3 and 1 (each within the scatter of the next); then compounds 2 and 4 (each within the scatter of the next).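

On this ring carbon, para to a large group, the two halogens do not behave alike: chloro in place of bromo gives a 4.6-fold higher number from compound 3 to compound 4 (0.66 log units; beyond the scatter), so a result for one halogen cannot simply be carried over to the other. Chloro in place of hydroxy gives a 2.3-fold higher number from compound 1 to compound 4 (0.36 log units; beyond the scatter), a step beyond the scatter where the bromo exchange stayed within it, and 4-chlorophenyl in place of 3-hydroxyphenyl gives a 1.1-fold higher number from compound 2 to compound 4 (0.04 log units; within the scatter), which leaves those two compounds level. No measurement available here explains why chloro and bromo part ways.

As far as these compounds go, whether fluoro or iodo on the same carbon would fall nearer to chloro or to bromo remains open, as does the outcome with an amine or a methoxy group there. Also open, from the compounds shown here alone, is whether the gap between the halogens recurs in a 3-chlorophenyl and 3-bromophenyl pair.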